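Two Limits and an Untested Acetoxy Swap

The source may hold more compounds than are shown below. What is called first, only, known or untested is meant among the compounds shown, and "the series" means these compounds.

Measured in (an ADME assay on T29 cells (Homo sapiens) for cytotoxicity, read by sulforhodamine B assay, with a stated time of 3 days; on this read-out lower numbers stand for stronger inhibition and higher numbers for weaker inhibition):
- compound 1 (`CC(C)Cn1cc(C=O)c2ccccc21`) gives (> 31600 nM), a limit and not a number
- compound 2 (`OCCc1cn(Cc2ccc(Cl)cc2)c2ccccc12`) gives (> 31600 nM), a limit and not a number

Compound 2 therefore has no exact position on the scale. Its reading in (this assay) is only the limit (> 31600 nM). The same limit holds for both measured compounds (the limit of > 31600 nM in this assay, at which 2 of the 2 values shown sit), so the data contain no numerical difference to learn from.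

The next compound is compound 3 (`CC(=O)OCc1cn(Cc2ccc(Cl)cc2)c2ccccc12`). It differs from compound 2 in one place (acetoxy in place of hydroxymethyl on a saturated chain carbon bound to an aromatic carbon), with acetoxy in place of hydroxymethyl on a saturated chain carbon bound to an aromatic carbon. Cut one bond further out, the same difference reads 2-hydroxyethyl to acetoxymethyl.

For the measured compounds named here, no step between measured compounds shows what such a change does. With only the limit for compound 2 (> 31600 nM) as a guide, the most likely outcome is no step beyond the usual scatter, and any readable shift would have to be toward stronger inhibition. The estimated step is small (an at least 1.0-fold lower number from compound 2 to compound 3 (0.02 log units; that floor lies within the scatter)). For compound 3 the expected value is (30000 nM), with an estimated range from (12000 nM) to (50000 nM).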

Compound 3, half-maximal inhibitory concentration: > 31600 nM
Compound 3 gave a limit, no number (the forecaster's own chance of this, stated with the estimate: 70%); at least 1.0-fold (0.02 log units) between middle value and limit.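

In this assay compound 3 gives > 31600 nM, which is a limit and not a number, so no step can be read between compound 2 and compound 3. All three compounds share one reading: the limit of > 31600 nM in this assay, at which 3 of the 3 values shown sit. From the compounds shown here alone, whether acetoxy in place of hydroxymethyl changes inhibition at all, and which change would yield a measurable number, stays open.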